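Shortening the Amide Side Chain of an Iodophenyl Anilide

The source may report more compounds than this note shows. Statements on the series, on what has been measured and on what is new or still open speak of the compounds shown alone.

Measured compounds:
- Compound 1 `O=C(CCl)Nc1ccc(I)cc1` — 5100 nM
- Compound 2 `O=C(CCCl)Nc1ccc(I)cc1` — 20000 nM

In a functional assay on M21 cells (Homo sapiens) for antiproliferative activity, with a stated time of 48 h (on this read-out higher numbers stand for weaker inhibition and lower numbers for stronger inhibition), compound 1 gives 5100 nM, and compound 2 gives 20000 nM. Going by the values given here, the one step between them, a 3.9-fold higher number from compound 1 to compound 2 (0.59 log units; beyond the scatter), is the only change on record, and compound 2 stands at the highest number of the two, with compound 1 as its nearest neighbour.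

Compound 3 `C=CC(=O)Nc1ccc(I)cc1` has not yet been measured. Relative to compound 2 the change is vinyl in place of 2-chloroethyl on a carbonyl carbon. Among the compounds with values here, the single measured step, a 3.9-fold higher number from compound 1 to compound 2 (0.59 log units; beyond the scatter), concerns a chlorine moved one carbon further out along the chain and does not touch the same kind of change, so it gives no direct guide; it only shows that changes on this chain can move the number beyond the usual scatter. Within the data shown here, compound 3 carries a chain shorter than that of compound 2 and closer in size to the one of compound 1, so a number nearer to that of compound 1 is the more natural expectation, though the direction is uncertain. The step from compound 2 to compound 3 is therefore expected to be a 4.0-fold lower number from compound 2 to compound 3 (0.60 log units; beyond the scatter). On this basis compound 3 is estimated at 5000 nM, within a range from 1000 nM to 25000 nM.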

Compound 3, half-maximal inhibitory concentration: 11000 nM
The estimate for compound 3 lay 2.2-fold (0.34 log units) below the measured number; the measured number falls inside the stated range.
By their numbers in this assay, from the lowest: compound 1; then compounds 3 and 2 (each within the scatter of the next).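

In this assay the exchange of 2-chloroethyl for vinyl on the carbonyl carbon gives a 1.8-fold lower number from compound 2 to compound 3 (0.26 log units; within the scatter) and so does not separate the two compounds, which shows that a side chain with no chlorine can sit level with a chlorine-bearing one at this position. Set against the chloromethyl group, vinyl gives a 2.2-fold higher number from compound 1 to compound 3 (0.33 log units; beyond the scatter) and this modest step leaves compound 1 as the strongest inhibitor of the three, since its steps to both other compounds lie beyond the scatter. Nothing available here accounts for these differences.

With only three side chains on the shared core, the position remains thinly mapped: a plain saturated ethyl chain would help show what the chlorine and the double bond each contribute, and a longer chain ending in chlorine would show how far the trend from compound 1 to compound 2 extends. From the compounds shown here alone, it also remains open how an amine or a carboxylic acid at the end of the side chain would read on this antiproliferative measure.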